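Imine series, maximal electroshock: chloro to methoxy step

The source may report more compounds than this note shows. Statements on the series, on what has been measured and on what is new or still open speak of the compounds shown alone.

Measured so far:
compound 1 `COc1ccc(/C=N/Cc2cccnc2)cc1O` gives 6.39 mg/kg in a functional assay on the whole organism (strain Swiss albino) with Mus musculus as the target, in the maximal electroshock model; on this read-out lower numbers stand for an effect already at smaller amounts and higher numbers for an effect only at larger amounts of compound
compound 2 `Clc1ccccc1/C=N/Cc1cccnc1` gives 11.7 mg/kg in this assay

Of the two numbers in this assay compound 2 holds the highest; compound 1 stands nearest, and the gap between them is within the scatter, so no order between the two is read from them.

Compound 3 `COc1ccccc1/C=N/Cc1cccnc1` differs from compound 2 by methoxy in place of chloro on an aromatic carbon. Going by the values given here, no step between measured compounds covers this exchange, so its size has to be guessed from the series as it stands. Compound 1 also carries a methoxy, alongside further substitution on the same ring, and gives 6.39 mg/kg, which lies within the scatter of compound 2. With a methoxy at the place of the chloro, and an additional hydrogen-bond acceptor entering, the expected step from compound 2 to compound 3 is a 1.2-fold lower number from compound 2 to compound 3 (0.09 log units; within the scatter), which is none beyond the scatter, if anything toward a smaller number. Compound 3 is therefore estimated at 9.5 mg/kg, with a range from 4.5 mg/kg to 20 mg/kg.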

Compound 3, dose for half-maximal effect: 11.7 mg/kg
Compound 3: middle estimate off by 1.2-fold (0.09 log units), on the low side, and the stated range covers the measured number.
By their numbers in this assay, from the lowest: compounds 1, 2 and 3 (each within the scatter of the next).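

In this assay, going by these compounds alone, methoxy in place of chloro on an aromatic carbon, ortho to a group of 9 heavy atoms, gives no change at the digits printed from compound 2 to compound 3 (within the scatter), and this is the first single-place step. At this place, then, exchanging one heavy atom for two and adding one hydrogen-bond acceptor leaves the dose read-out without a shift that can be told from the scatter, so chloro and methoxy cannot be separated here on this measure. Nothing measured on these compounds explains why the two groups give the same number.

Open, from the compounds shown here alone, is whether a group of a different kind at this place, such as an amine, a carboxylic acid or a longer chain like butoxy, would move the number in this assay beyond the scatter. Within the data shown here, also open is what the further substitution on the ring of compound 1 contributes, since no single-place step connects compound 1 to the other two, and whether the flat result for chloro and methoxy holds elsewhere on the ring.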